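The compounds below may be only part of what the source reports. "The series", "measured", "known", "first", "only" and "open" are said of these compounds alone.

Four spiro compounds built on one shared core make up the set. Compound 1 `Cc1ccc2c(c1)C1(C(=O)N2C)C(C#N)=C(N)Oc2cc3oc(-c4ccccc4)cc(=O)c3c(O)c21` carries a methyl on the amide nitrogen and a methyl on the aromatic ring; in a functional assay on K562 cells (Homo sapiens) for antiproliferative activity, read by MTT assay, with a stated time of 48 h (a higher number here means a weaker inhibitor, a lower number a stronger inhibitor), compound 1 gives 5870 nM. Compound 2 `Cc1cccc2c1N(Cc1ccccc1)C(=O)C21C(C#N)=C(N)Oc2cc3oc(-c4ccccc4)cc(=O)c3c(O)c21` carries a benzyl on the amide nitrogen instead. In this assay compound 2 reaches only the limit > 50000 nM, which is not a number. Compound 3 `COc1ccc2c(c1)C1(C(=O)N2Cc2ccccc2)C(C#N)=C(N)Oc2cc3oc(-c4ccccc4)cc(=O)c3c(O)c21` keeps the benzyl and carries a methoxy on the aromatic ring. For the measured compounds named here, for compound 3 this assay again reports only the limit > 50000 nM, so compound 3 stands at the limit of > 50000 nM in this assay, at which 2 of the 3 values shown sit, and has no number of its own, and no step between it and compound 1 or compound 2 can be drawn.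

Compound 4 `N#CC1=C(N)Oc2cc3oc(-c4ccccc4)cc(=O)c3c(O)c2C12C(=O)N(Cc1ccccc1)c1ccc(Br)cc12` differs from compound 3 in one place: bromo in place of methoxy on an aromatic carbon, with the benzyl on the amide nitrogen retained. Because compound 2 sits at > 50000 nM and compound 3 sits at > 50000 nM, both benzyl-bearing compounds leave no number to measure a step from, and the bromo is expected to give at most a small step in either direction, within the scatter, as an at least 1.2-fold lower number from compound 3 to compound 4 (0.09 log units; that floor lies within the scatter). Compound 4 is therefore expected to give about 40000 nM, between 10000 nM and 120000 nM, with a fair chance that this assay again reports only a limit.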

Compound 4, half-maximal inhibitory concentration: 36400 nM
The estimate for compound 4 lay 1.1-fold (0.04 log units) above the measured number, and the stated range covers the measured number.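

Compound 4 is the only compound shown with a benzyl on the amide nitrogen that has a number of its own: in this assay compound 4 gives 36400 nM. On this aromatic carbon, bromo in place of methoxy therefore gives an at least 1.3-fold lower number from compound 3 to compound 4 (0.13 log units; that floor lies within the scatter), so the change can be read only as a floor and not as a true size, and that floor alone does not establish a real difference between the two compounds. The other end of the step is a limit and not a number, which is why only a floor can be given: the limit of > 50000 nM in this assay, at which 2 of the 4 values shown sit.

The compounds shown leave open how large the step really is, and what a chloro, an amine or a carboxylic acid would give on this same aromatic carbon with the benzyl retained. They also leave open what bromo would give on this carbon with a methyl on the amide nitrogen in place of the benzyl, a pairing that would allow a comparison with a number at both ends.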